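The source may report more compounds than this note shows. Statements on the series, on what has been measured and on what is new or still open speak of the compounds shown alone.

Measured so far in a functional assay on PC-3 cells (Homo sapiens) for antiproliferative activity, read by MTT assay, with a stated time of 72 h; on this read-out higher numbers stand for weaker inhibition and lower numbers for stronger inhibition:
Compound 1 `CCOC(=O)c1csc2nc(CN3CCN(C)CC3)c(-c3ccc(OC)cc3)n12`: 69400 nM
Compound 2 `Cc1ccc(-c2c(CN3CCCCC3)nc3scc(C(=O)O)n23)cc1`: 16600 nM

Of these two compounds, compound 2 holds the lower number, and the gap to compound 1 lies beyond the scatter, so it is the stronger inhibitor of the pair, though both numbers are high. The next compound, compound 3 `COc1ccc(-c2c(CN3CCCCC3)nc3scc(C(=O)O)n23)cc1`, has not yet been measured. It departs from compound 2 in one place only: methoxy in place of methyl on an aromatic carbon. This puts methoxy in place of methyl on an aromatic carbon, turning 4-methylphenyl into 4-methoxyphenyl. Within the data shown here, no measured pair shows what this change does in this assay, so the expectation rests on the small size of the change alone: no step beyond the scatter, in neither direction. The expected outcome is a 1.1-fold higher number from compound 2 to compound 3 (0.04 log units; within the scatter). For compound 3 the estimated value is 18000 nM, with an expected range from 7000 nM to 46000 nM.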

Compound 3, half-maximal inhibitory concentration: 73100 nM
For compound 3 the middle estimate is 4.1-fold (0.61 log units) below the measured one; measured number outside the range, above it.
By their numbers in this assay, from the lowest: compound 2; then compounds 1 and 3 (each within the scatter of the next).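

Going from 4-methylphenyl to 4-methoxyphenyl, on the aromatic ring para to a large group, gives a 4.4-fold higher number from compound 2 to compound 3 (0.64 log units; beyond the scatter) in this assay. This first single-place comparison shows that the position is sensitive to a small change: with the rest of the structure held fixed, the methyl compound holds the lower number, and the step lies beyond the scatter. Nothing available accounts for this step.

Among these compounds, the single pair cannot separate the contribution of the entering oxygen from that of the larger group as a whole. It also leaves open how other groups at this position would stand, such as a hydroxyl, a chlorine, an ethyl chain or an amine, and whether the same step would recur with another group in place of the carboxylic acid.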